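This account rests on a few compounds, and the source may have more. Where it says the series, first, only, none or still open, it means among the compounds named here.

In a functional assay on HL-60 cells (Homo sapiens) for antiproliferative activity, with a stated time of 72 h (a lower number here means a stronger inhibitor of growth, a higher number a weaker inhibitor of growth), compound 1 `C=C(C)C(=O)c1ccc(OC(C)C(=O)O)cc1C` gives > 60000 nM, which is a limit and not a number. Compound 2 `C=C(C)C(=O)c1ccc(OC(C)C(=O)O)cc1Br` gives > 60000 nM, also a limit. Compound 3 `C=C(CC)C(=O)c1ccc(OC(C)C(=O)O)cc1Cl` gives > 60000 nM, again a limit. Compound 3 therefore has no exact value, and the whole set stands at the limit of > 60000 nM in this assay, at which 3 of the 3 values shown sit. Compound 4 `C=C(C)C(=O)c1ccc(OC(C)C(=O)O)cc1Cl` differs from compound 3 by hydrogen in place of methyl on a saturated chain carbon bound to a double-bonded chain carbon: ethyl to methyl, with hydrogen in place of methyl on a saturated chain carbon bound to a double-bonded chain carbon. Among the measured compounds shown here, the one measured step, a step that the two limits leave unreadable from compound 1 to compound 2, is a different change and offers no readable size. No shift beyond the scatter, in either direction, is therefore expected, and the estimated step is a number no higher from compound 3 to compound 4 (the limit leaves the size open). For compound 4 the expected value is 60000 nM, with an estimated range from 30000 nM to 120000 nM.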

Compound 4, concentration for 50% growth inhibition: > 60000 nM
Compound 4 was reported as a limit (the forecaster's own chance of this, stated with the estimate: 85%); the middle value lies on the limit itself.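

No step can be read from compound 4 to compound 1, compound 2 or compound 3, as each result is a limit and not a number: the limit of > 60000 nM in this assay, at which 4 of the 4 values shown sit.

The compounds shown leave open how strongly each one inhibits growth in this assay, and whether any of these changes alters that.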